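A few compounds are considered here, and "the series" means these few. Any claim that something is new, unique, unknown or untested is made for them only; others in the source may bear on it.

Working notes on the series. For the measured compounds named here, compound 1, `CC1CCN(c2c(S(=O)(=O)c3ccccc3)cnc3ccc(F)cc23)CC1`, has the lower number of the two measured members: in an assay on isolated protein for displacement of a labelled ligand from metabotropic glutamate receptor 5 (Homo sapiens), with a stated time of 60 min, tested at 1 uM (a lower number here means less inhibition, a higher number more inhibition at the concentration tested (going by the name of the read-out)), compound 1 gives 40%, the lowest of the two numbers in hand. Its nearest neighbour is compound 2, `Cc1ccc2ncc(S(=O)(=O)c3ccccc3)c(N3CCC(C)CC3)c2c1`, which in this assay gives 67%. Going by the values given here, the one measured step, a number 27 percentage points higher from compound 1 to compound 2 (beyond the scatter), follows methyl in place of fluoro on an aromatic carbon, a change on the shared core and not on the sulfonyl substituent.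

The next member, compound 3, `COc1ccc(S(=O)(=O)c2cnc3ccc(F)cc3c2N2CCC(C)CC2)cc1Cl`, differs from compound 1 as follows:
3-chloro-4-methoxyphenyl in place of phenyl on a sulfonyl sulfur
Among the compounds with values here, no measured pair changes the group on the sulfonyl sulfur, so the single step in hand does not bear directly on this change; it shows only that a one-group change can move the read-out in this assay by a modest amount. With no guide to direction, the expected step of a number 5 percentage points higher from compound 1 to compound 3 (within the scatter) is small, and the estimate is held wide. Compound 3 is therefore expected to give 45% in this assay, within a range of 20% to 70%.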

Compound 3, a percentage reported as inhibition, at one concentration (the size of the read-out at that concentration, not a potency): 82%
Beside the measured number, compound 3's estimate is 37 percentage points below it; measured number outside the range, above it.
By their numbers in this assay, from the lowest: compound 1; then compound 2; then compound 3.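

In this assay, the group on the sulfonyl sulfur is now shown to affect the read-out: 3-chloro-4-methoxyphenyl in place of phenyl gives a number 42 percentage points higher from compound 1 to compound 3 (beyond the scatter), a step rated large. For the compounds shown here, the only earlier step, a number 27 percentage points higher from compound 1 to compound 2 (beyond the scatter), is rated modest and follows a change on the shared core, so it left the sulfonyl substituent untested; the series now has two places where a single change moves the number beyond the scatter. Nothing in hand accounts for the higher number that comes with the 3-chloro-4-methoxyphenyl group.

Chlorine and methoxy enter together in compound 3, so the compounds shown cannot divide the step between them, and they do not tell whether either group alone would give a step beyond the scatter, or how a carboxylic acid or an amine on the same phenyl ring would read. Also open, on these data alone, is whether methyl in place of fluoro on the aromatic carbon of the core would raise the number again when 3-chloro-4-methoxyphenyl sits on the sulfonyl sulfur.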